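A few compounds are considered here, and "the series" means these few. Any claim that something is new, unique, unknown or untested is made for them only; others in the source may bear on it.

Measured so far:
- compound 1, `O=C(CSc1nc2ccccc2s1)N/N=C/c1ccc(Oc2ccc(F)cc2)cc1`: 5.5
- compound 2, `Cc1cc(Oc2ccc(/C=N/Nc3nc4ccccc4s3)cc2)ccc1Cl`: 5.5

Both were measured in a physicochemical assay for lipophilicity, in phosphate buffer, measured as octanol-water partition, with a stated time of 24 h; a higher number here means a more lipophilic compound, a lower number a more polar compound. In that assay compound 1 gives 5.5, and compound 2 gives 5.5. The two values are level at the digits given, within the usual scatter of repeated measurements, so the data show no order between compound 1 and compound 2. Within the data shown here, no pair of measured compounds differs in a single place, so no measured step is known.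

Compound 3, `O=C(CSc1nc2ccccc2s1)N/N=C/c1ccc(Oc2ccc3ccccc3c2)cc1`, has not yet been measured. It differs from compound 1 in one place: naphthalen-2-yl in place of 4-fluorophenyl on an oxygen on an aromatic ring. The group that leaves carries one aromatic ring and the group that enters carries two, with no change in donors, acceptors or charge.

Among the measured compounds shown here, with no measured step to lean on, the expected step of a number 1.00 log units higher from compound 1 to compound 3 (beyond the scatter) is upward and beyond the scatter. Compound 3 is expected to give 6.5, within a range from 6 to 7.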

Compound 3, partition coefficient: 5.9
Beside the measured number, compound 3's estimate is 0.60 log units above it, outside the stated range (below it).
By their numbers in this assay, from the lowest: compounds 1 and 2 (each within the scatter of the next); then compound 3.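

In this assay, naphthalen-2-yl in place of 4-fluorophenyl on an oxygen on an aromatic ring gives a number 0.40 log units higher from compound 1 to compound 3 (beyond the scatter), a modest step. The earlier compounds shown here offered no single change to read, and this one shows that the number responds at this position when one six-membered aromatic ring of carbon only gives way to two, with no change in donors, acceptors or charge. No measurement here bears on why the number moves in this way.

This one step cannot separate the added ring from the loss of the fluorine, as the two come together in this change. On these data alone, whether a plain phenyl, a cyclohexyl, or a group carrying an amine or a carboxylic acid at this place would raise or lower the number remains open.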